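From a limit value to a new ester side chain

The source may hold more compounds than are shown below. What is called first, only, known or untested is meant among the compounds shown, and "the series" means these compounds.

- Compound 1 `CCn1c(C(=O)NCCN(C)C)ccc1C(CC)(CC)c1ccc(OCCC(O)(CC)CC)c(C)c1` gives 990 nM as a measured number
- Compound 2 `CCC(C)C(NC(=O)c1ccc(C(CC)(CC)c2ccc(OCCC(O)(CC)CC)c(C)c2)n1CC)C(=O)OC` gives > 50000 nM as a limit

In an ADME assay on L02 cells (Homo sapiens) for antiproliferative activity, read by MTT assay, with a stated time of 48 h (on this read-out higher numbers stand for weaker inhibition and lower numbers for stronger inhibition), compound 2 gives > 50000 nM as a limit and not as a number. Compound 3 `CCOC(=O)CN(C)C(=O)c1ccc(C(CC)(CC)c2ccc(OCCC(O)(CC)CC)c(C)c2)n1CC` differs from compound 2 on a carbonyl carbon (a group of 8 heavy atoms (5 carbon, 1 nitrogen, 2 oxygen; no ring) in place of a group of 10 heavy atoms (7 carbon, 1 nitrogen, 2 oxygen; no ring), on a carbonyl carbon). The group that enters is ((ethoxycarbonyl)methyl)(methyl)amino, with no net charge.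

For the measured compounds named here, one measured step bears on this change: an at least 50-fold higher number from compound 1 to compound 2 (1.70 log units; beyond the scatter) on an amide-type nitrogen, which is large and beyond the scatter. Compound 3 keeps an ester group, as compound 2 does, and compound 1 has none. A return towards 990 nM for compound 1 therefore seems unlikely, and no step beyond the scatter is expected. The expected change is a number no higher from compound 2 to compound 3 (the limit leaves the size open) in this assay with no clear direction. For compound 3 the estimate is 50000 nM with an expected range of 15000 nM to 150000 nM in this assay and a limit reading is quite possible.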

Compound 3, half-maximal inhibitory concentration: 1990 nM
Compound 3: middle estimate off by 25-fold (1.40 log units), on the high side, and the stated range ends above it.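

In this assay, an ester in this side chain does not by itself go with a limit reading, since the step is an at least 25-fold lower number from compound 2 to compound 3 (1.40 log units; beyond the scatter). An amine side chain is not needed for this level of inhibition either, as ((ethoxycarbonyl)methyl)(methyl)amino in place of (2-(dimethylamino)ethyl)amino gives a 2.0-fold higher number from compound 1 to compound 3 (0.30 log units; within the scatter). The reading for compound 2 is a limit and not a number, so the true size of its gap to compound 3 is unknown: the limit of > 50000 nM in this assay, at which 1 of the 3 values shown sits.

Compound 3 has no amide hydrogen, unlike compound 2, and its side chain also differs in the rest of its atoms, so the compounds shown cannot tell which of these differences matters. A carboxylic acid in place of the ester, or a longer chain on the same nitrogen, would help to separate these effects.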